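This account rests on a few compounds, and the source may have more. Where it says the series, first, only, none or still open, it means among the compounds named here.

Working notes on the series. The shared core of compound 1 `FC(F)(F)c1ccc(Nc2ncnc3sc(Nc4c(Cl)cccc4Cl)nc23)cc1` carries a 2,6-dichlorophenyl on one ring nitrogen and a 4-(trifluoromethyl)phenyl on another. In a functional assay on HEK293 cells for antagonist activity at transient receptor potential cation channel subfamily V member 1 (Homo sapiens), read by calcium flux (on this read-out higher numbers stand for weaker inhibition and lower numbers for stronger inhibition), compound 1 gives 12 nM. For the measured compounds named here, compound 2 `FC(F)(F)c1ccc(Nc2ncnc3sc(Nc4ccccc4C(F)(F)F)nc23)cc1` differs in one place, and in this assay compound 2 gives 74 nM; the step of a 6.2-fold higher number from compound 1 to compound 2 (0.79 log units; beyond the scatter) is the only measured step so far. Compound 1 therefore stands at the lowest of the two numbers.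

Compound 3 `CC(C)N1CCN(c2nc(Nc3ccc(C(F)(F)F)cc3)c3nc(Nc4c(Cl)cccc4Cl)sc3n2)CC1` carries the change (4-isopropylpiperazin-1-yl in place of hydrogen on an aromatic carbon). This change sits on an aromatic carbon between two ring nitrogen atoms of the core and leaves both anilino groups of compound 1 untouched. Going by the values given here, the one measured step, from compound 1 to compound 2, altered the aryl on a nitrogen and not this position, so no step on record bears on the change to compound 3; the size of the step of a 1.7-fold higher number from compound 1 to compound 3 (0.22 log units; within the scatter) is expected to be small and its direction is uncertain. Compound 3 is accordingly estimated at 20 nM in this assay, with a range from 5 nM to 80 nM.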

Compound 3, half-maximal inhibitory concentration: 184 nM
Beside the measured number, compound 3's estimate is 9.2-fold (0.96 log units) below it, and the stated range ends below it.
By their numbers in this assay, from the lowest: compound 1; then compound 2; then compound 3.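

In this assay the aromatic carbon between two ring nitrogen atoms now has a measured step of its own: 4-isopropylpiperazin-1-yl in place of hydrogen gives a 15-fold higher number from compound 1 to compound 3 (1.19 log units; beyond the scatter) and so weaker inhibition, although the aryl groups on both nitrogens stay as they are in compound 1. Until now only the aryl on a nitrogen had been varied, so this is the first sign that the position itself can move the read-out by a large step, and compound 1 stays the strongest inhibitor of the compounds shown. No measurement on hand explains why this group costs so much at this carbon.

From the compounds shown here alone, whether the loss belongs to any substituent at this position or to this particular group stays open, since a single group cannot separate the two. A small group such as methyl or a plain amine on the same carbon, or a morpholine ring or a piperazine without the isopropyl, would show whether the number can stay near that of compound 1.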